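Compound 3: an azetidine amide in rat clearance

A few compounds are considered here, and "the series" means these few. Any claim that something is new, unique, unknown or untested is made for them only; others in the source may bear on it.

Values from an ADME assay on the whole organism for pharmacokinetics, with Rattus norvegicus as the target (on this read-out higher numbers stand for fast clearance and lower numbers for slow clearance), so far:
Compound 1 (`C[C@@H](CO)Oc1cc(Oc2ccc(C(=O)N(C)C)cc2)cc(C(=O)Nc2ccn(C)n2)c1`) gives (31 mL/min/kg)
Compound 2 (`COC[C@H](C)Oc1cc(Oc2ccc(C(=O)N(C)C)cc2)cc(C(=O)Nc2cc[nH]n2)c1`) gives (34 mL/min/kg)

Compound 1 and compound 2 lie within the usual scatter of each other, so compound 1 does not stand apart from compound 2 on these numbers. Among the compounds with values here, these two compounds differ in more than one place, and no measured pair isolates a single change. Compound 3 (`C[C@@H](CO)Oc1cc(Oc2ccc(C(=O)N3CCC3)cc2)cc(C(=O)Nc2ccn(C)n2)c1`) differs from compound 1 in one place, by azetidin-1-yl in place of dimethylamino on a carbonyl carbon in the structure, which is azetidin-1-yl in place of dimethylamino on a carbonyl carbon. Within the data shown here, no measured step speaks to this change, so no step beyond the scatter is expected in this assay in either direction. The estimated 1.0-fold lower number from compound 1 to compound 3 (0.01 log units; within the scatter) is expected to remain within the scatter. Compound 3 is expected at 30 mL/min/kg within an estimated range from 16 mL/min/kg to 55 mL/min/kg in this read-out.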

Compound 3, clearance in the Rattus norvegicus assay: 14 mL/min/kg
The estimate for compound 3 lay 2.1-fold (0.33 log units) above the measured number; the whole stated range lies above it.
By their numbers in the Rattus norvegicus assay, from the lowest: compound 3; then compounds 1 and 2 (each within the scatter of the next).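

Azetidin-1-yl in place of dimethylamino on a carbonyl carbon gives the first single change that can be read in the Rattus norvegicus assay: a 2.2-fold lower number from compound 1 to compound 3 (0.35 log units; beyond the scatter), which shows that clearance responds to this position, something the earlier pair could not show. In a physicochemical assay for solubility (on this read-out lower numbers stand for lower solubility and higher numbers for higher solubility), compound 1 gives > 1000000 nM, which is a limit of the assay and not a number. In the physicochemical assay compound 3 gives 350000 nM. The same change gives an at least 2.8-fold lower number from compound 1 to compound 3 (0.45 log units; beyond the scatter) in the physicochemical assay, and this step starts from that limit: the limit of > 1000000 nM in the physicochemical assay, at which 1 of the 2 values shown sits.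

From the compounds shown here alone, it remains open whether the step in the Rattus norvegicus assay would carry over to compound 2, which has the same dimethylamino group, and whether pyrrolidin-1-yl or morpholin-4-yl on the same carbonyl carbon would follow azetidin-1-yl. The compounds shown also do not tell why the clearance moved.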